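The source may hold more compounds than are shown below. What is called first, only, known or untested is meant among the compounds shown, and "the series" means these compounds.

Compound 2 `Fc1ccccc1N1CCN(Cc2nc3ccccc3[nH]2)CC1` is the higher of the two compounds measured in an assay on HEK293 cells with D(4) dopamine receptor (Homo sapiens) as the target, read by FLIPR (a higher number here means a larger maximal response, a lower number a smaller maximal response), where compound 2 gives 42%. Among the measured compounds shown here, its only neighbour is compound 1 `O=[N+]([O-])c1ccccc1N1CCN(Cc2nc3ccccc3[nH]2)CC1`, which in this assay gives 40%, so that a number 2 percentage points higher from compound 1 to compound 2 (within the scatter) and the two stand within the scatter of each other. Compound 3 `CSc1ccccc1N1CCN(Cc2nc3ccccc3[nH]2)CC1` differs from compound 2 by methylsulfanyl in place of fluoro on an aromatic carbon. For the measured compounds named here, the one measured step on this same aromatic carbon, the exchange of nitro for fluoro, left the maximal response essentially unchanged, so compound 3 is expected to show no change at the digits printed from compound 2 to compound 3 (within the scatter), with an estimate of 42% for compound 3, ranging from 25% to 60%.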

Compound 3, largest response reached (reported as efficacy), in percent of the reference or control that the assay uses: 42%
For compound 3 middle estimate and measured number coincide at the digits printed; the range from low to high includes it.
By their numbers in this assay, from the lowest: compounds 1, 2 and 3 (each within the scatter of the next).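

In this assay methylsulfanyl in place of fluoro gives no change at the digits printed from compound 2 to compound 3 (within the scatter) and methylsulfanyl in place of nitro gives a number 2 percentage points higher from compound 1 to compound 3 (within the scatter) and these steps add a third group to this aromatic carbon. The entering group brings a sulfur and one more heavy atom than fluoro, yet all three compounds stay within the scatter of one another. Nothing available explains this insensitivity. The compounds shown leave open whether an amine, a carboxylic acid or a longer chain such as butylsulfanyl on this carbon would shift the maximal response.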